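Meta-substituted anilides on the diazabicyclic pyridine core

This account rests on a few compounds, and the source may have more. Where it says the series, first, only, none or still open, it means among the compounds named here.

Measured compounds:
- compound 1 `O=C(Nc1cccc(F)c1)c1cncc(N2CC3CC(C2)N3)c1`: 0.044 nM
- compound 2 `CCc1cccc(NC(=O)c2cncc(N3CC4CC(C3)N4)c2)c1`: 1.3 nM

Within the data shown here, in an assay on membranes from Cerebral cortex for displacement of a labelled ligand from Neuronal acetylcholine receptor; alpha4/beta2 (Rattus norvegicus) (a higher number here means a weaker inhibitor, a lower number a stronger inhibitor), compound 1 gives 0.044 nM, the lowest of the two numbers so far; its nearest neighbour is compound 2 with 1.3 nM. Among the measured compounds shown here, the one change already measured, a 30-fold higher number from compound 1 to compound 2 (1.47 log units; beyond the scatter), shows that replacing the small halogen on the anilide ring by a larger carbon group costs a large amount of binding.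

Compound 3 `COc1cccc(NC(=O)c2cncc(N3CC4CC(C3)N4)c2)c1` is not yet measured. It differs from compound 1 by methoxy in place of fluoro on an aromatic carbon. For the measured compounds named here, the only step that bears on this is the fluoro-to-ethyl exchange, which was large and in the weakening direction. Methoxy is intermediate in size between fluoro and ethyl, so a weakening step, smaller than that one but likely beyond the scatter, is expected: a 6.8-fold higher number from compound 1 to compound 3 (0.83 log units; beyond the scatter). For compound 3 in this assay the estimate is 0.3 nM, within a range of 0.08 nM to 1.5 nM.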

Compound 3, inhibition constant: 0.56 nM
Compound 3: the middle estimate sits 1.9-fold (0.27 log units) below what was measured, and the stated range covers the measured number.
By their numbers in this assay, from the lowest: compound 1; then compound 3; then compound 2.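

In this assay, the cost of replacing fluoro on this aromatic carbon, meta to a large group, is no longer tied to ethyl alone: methoxy in place of fluoro gives a 13-fold higher number from compound 1 to compound 3 (1.10 log units; beyond the scatter). The two replacements are also distinguishable from each other, with methoxy in place of ethyl giving a 2.3-fold lower number from compound 2 to compound 3 (0.37 log units; beyond the scatter), a modest step beside the large one from fluoro. No measured data explain either step.

Still open, as far as these compounds go, is whether chloro, hydroxyl or an amine on this carbon would come close to fluoro, or whether a longer chain or a longer ether would lie beyond ethyl. The compounds shown also leave open whether the order fluoro, methoxy, ethyl would hold on another carbon of the same ring.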